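This account rests on a few compounds, and the source may have more. Where it says the series, first, only, none or still open, it means among the compounds named here.

Working notes on the series. In a functional assay on NIH3T3 cells (Mus musculus) (a higher number here means that more compound is needed for the effect, a lower number that less compound is needed), compound 1 (`Cn1cncc1C(OCc1ccc(C#N)cc1-c1ccccc1)c1ccc(C#N)cc1`) gives 140 nM, compound 2 (`Cn1cncc1C(OCc1ccc(C#N)cc1C#CC1(O)CCCCC1)c1ccc(C#N)cc1`) gives 1.93 nM and compound 3 (`Cn1cncc1C(OCc1ccc(C#N)cc1C#Cc1ccc([N+](=O)[O-])cc1)c1ccc(C#N)cc1`) gives 36 nM. Compound 3 therefore holds the second highest of the three numbers, with compound 1 nearest to it and compound 2 furthest.

Compound 4 (`Cn1cncc1C(OCc1ccc(C#N)cc1C#Cc1ccccc1)c1ccc(C#N)cc1`) differs from compound 3 by one change: hydrogen in place of nitro on an aromatic carbon, para to a large group (hydrogen in place of nitro on an aromatic carbon).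

Going by the values given here, no measured pair isolates the nitro group, so the evidence is indirect. Putting 2-(4-nitrophenyl)ethynyl in place of phenyl gives a 3.9-fold lower number from compound 1 to compound 3 (0.59 log units; beyond the scatter). Putting 4-nitrophenyl in place of 1-hydroxycyclohexyl on the triple-bonded carbon gives a 19-fold higher number from compound 2 to compound 3 (1.27 log units; beyond the scatter). Putting 2-(1-hydroxycyclohexyl)ethynyl in place of phenyl gives a 73-fold lower number from compound 1 to compound 2 (1.86 log units; beyond the scatter). These steps show that the group on the triple bond can move the number widely, but each exchanges a whole group, whereas the coming change keeps the phenyl ring on the triple bond.

No step beyond the scatter is expected in this assay, and the expected shift is a 1.4-fold lower number from compound 3 to compound 4 (0.16 log units; within the scatter). The range stays wide, as only compound 3 at 36 nM lies close in structure. For compound 4 the estimate is 25 nM, with an expected range of 7 nM to 90 nM.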

Compound 4, half-maximal effective concentration: 0.1 nM
Compound 4: the middle estimate sits 250-fold (2.40 log units) above what was measured; measured number outside the range, below it.
By their numbers in this assay, from the lowest: compound 4; then compound 2; then compound 3; then compound 1.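

In this assay the place on the aromatic carbon para to a large group proves far more sensitive than compounds 1 to 3 could show: hydrogen in place of nitro gives a 360-fold lower number from compound 3 to compound 4 (2.56 log units; beyond the scatter), a larger step than any among those three compounds. The high number of compound 3 therefore cannot be read as a limit on aromatic rings at the triple bond, since phenyl in place of 1-hydroxycyclohexyl gives a 19-fold lower number from compound 2 to compound 4 (1.29 log units; beyond the scatter) and 2-phenylethynyl in place of phenyl gives a 1400-fold lower number from compound 1 to compound 4 (3.15 log units; beyond the scatter), leaving the unsubstituted ring on the triple bond with the lowest number of the series. Nothing at hand accounts for the size of these steps.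

As far as these compounds go, it remains open whether the loss belongs to nitro alone or would recur with another group at this place, such as an amine, a fluorine atom, a methoxy group or a carboxylic acid. Also open, from the compounds shown here alone, is how a plain cyclohexyl ring without the hydroxyl, or a longer chain, on the triple-bonded carbon would compare with the phenyl ring of compound 4.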